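Nitro to Amino at Two Places on One Scaffold

The source may report more compounds than this note shows. Statements on the series, on what has been measured and on what is new or still open speak of the compounds shown alone.

Measured compounds in an assay on COS-7 cells for inhibition of Fatty-acid amide hydrolase 1 (Homo sapiens), read by scintillation counting, with a stated time of 10 min, tested at 10 uM; on this read-out lower numbers stand for less inhibition and higher numbers for more inhibition at the one concentration tested (going by the name of the read-out):
compound 1, `COc1nn(Cc2ccccc2[N+](=O)[O-])c(=O)o1`, 36%
compound 2, `COc1nn(Cc2ccc([N+](=O)[O-])cc2)c(=O)o1`, 18%
compound 3, `COc1nn(Cc2ccccc2N)c(=O)o1`, 8%

Compound 1 and compound 3 differ in one place, (amino in place of nitro on an aromatic carbon), and that change made a number 28 percentage points lower from compound 1 to compound 3 (beyond the scatter). Compound 2 has the same atoms as compound 1 joined differently; the difference between the two cores is not broken down here. Compound 4, `COc1nn(Cc2ccc(N)cc2)c(=O)o1`, relates to compound 2 by amino in place of nitro on an aromatic carbon. This is the same kind of change as before, not the same: in compound 3 the amino sits ortho to a group of 9 heavy atoms, in compound 4 para to a group of 9 heavy atoms. Because the earlier change gave a number 28 percentage points lower from compound 1 to compound 3 (beyond the scatter), and because compound 2 starts from 18%, a step of a number 13 percentage points lower from compound 2 to compound 4 (beyond the scatter) is expected in this assay. Compound 4 is therefore estimated at 5%, likely between -8% and 20%.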

Compound 4, a percentage reported as inhibition, at one concentration (the size of the read-out at that concentration, not a potency): 34%
Beside the measured number, compound 4's estimate is 29 percentage points below it; the measured number lies above the stated range.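

In this assay, amino in place of nitro, para to a group of 9 heavy atoms, gave a number 16 percentage points higher from compound 2 to compound 4 (beyond the scatter), and the change did not carry from one core to the other, even in direction: the same change on two cores in this assay, a number 28 percentage points lower (beyond the scatter) from compound 1 to compound 3 and a number 16 percentage points higher (beyond the scatter) from compound 2 to compound 4, 44 percentage points apart, beyond the scatter of two such steps. Within these compounds, then, the step seen on one core is no safe guide to the step on the other. Two pairs do not show what lies behind the difference, nor which way the change would go on any further core.

The compounds shown carry only nitro or amino on the aromatic ring, so how a nitrile or a carboxylic acid there would read remains open. Each number also comes from a single concentration, which leaves the potency of all these compounds open.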